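This account rests on a few compounds, and the source may have more. Where it says the series, first, only, none or still open, it means among the compounds named here.

Compound 1 `CC(=O)N1CCN(c2nnc3nncn3n2)CC1` gives 13100 nM
Compound 2 `O=C(C1CCCCC1)N1CCN(c2nnc3nncn3n2)CC1` gives 1900 nM

Both compounds were tested in a functional assay on BeWo cells (Homo sapiens) for inhibition, read by MTT assay, with a stated time of 72 h (on this read-out lower numbers stand for stronger inhibition and higher numbers for weaker inhibition), as the only measure. Compound 2 has the lower of the two numbers. Among the compounds with values here, the single measured step is a 6.9-fold lower number from compound 1 to compound 2 (0.84 log units; beyond the scatter) and it is also the only change so far at this place on the molecule.

Compound 3 `CCCCC(=O)N1CCN(c2nnc3nncn3n2)CC1` keeps the shared core and exchanges one group. The exchange, butyl in place of cyclohexyl on a carbonyl carbon, is spelled out as butyl in place of cyclohexyl on a carbonyl carbon and leaves the rest of the molecule untouched.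

No other group has been measured here, so one step carries the whole argument. Compound 2 at 1900 nM and compound 1 at 13100 nM mark the two ends of that comparison, and butyl is neither group. In this assay a partial return toward compound 1 is therefore expected, with a rise smaller than the earlier step and possibly close to the scatter. The expected step is a 2.1-fold higher number from compound 2 to compound 3 (0.32 log units; beyond the scatter) on this reasoning. Compound 3 is estimated at 4000 nM, with an expected range from 1800 nM to 9000 nM as a rough guide.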

Compound 3, half-maximal inhibitory concentration: 1720 nM
Compound 3: the middle estimate sits 2.3-fold (0.37 log units) above what was measured; the measured number lies below the stated range.
By their numbers in this assay, from the lowest: compounds 3 and 2 (each within the scatter of the next); then compound 1.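

In this assay, the open butyl chain and the cyclohexyl ring cannot be told apart: the step reads (a 1.1-fold lower number from compound 2 to compound 3 (0.04 log units; within the scatter)), so the ring itself is not required to keep the number reached with cyclohexyl, even though the group goes from 6 heavy atoms to 4. Set against the methyl group, the butyl chain gives (a 7.6-fold lower number from compound 1 to compound 3 (0.88 log units; beyond the scatter)), which sits alongside the earlier step (a 6.9-fold lower number from compound 1 to compound 2 (0.84 log units; beyond the scatter)) and shows that a lower number at this carbonyl carbon is available from a ring-free group as well as from a ring. Nothing at hand bears on why the two groups read alike.

The compounds shown leave open how short the chain can become before the number climbs back toward that of the methyl group, as an ethyl or propyl group could show, and whether a longer chain such as octyl would hold the number or change it. They also leave open how a phenyl ring, or a butyl chain ending in an amine or a carboxylic acid, would read in this assay.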